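The compounds below may be only part of what the source reports. "The series", "measured", "known", "first", "only" and "open" are said of these compounds alone.

Measured compounds in an ADME assay on MT4 cells (Homo sapiens) for cytotoxicity, read by MTT assay, with a stated time of 5 days; on this read-out higher numbers stand for lower toxicity in this test and lower numbers for higher toxicity in this test:
Compound 1, `Cc1cc(/C=C/C#N)cc(C)c1Oc1nc(Nc2ccc(CN3CCN(S(N)(=O)=O)CC3)cc2)nc2sccc12`: compound 1 gives > 217000 nM, a limit of the assay rather than a number.
Compound 2, `Cc1cc(/C=C/C#N)cc(C)c1Oc1nc(Nc2ccc(N3CCNCC3)cc2)nc2sccc12`: compound 2 gives 4740 nM.
Compound 3, `Cc1cc(/C=C/C#N)cc(C)c1Oc1nc(Nc2ccc(N3CCCC(NS(N)(=O)=O)C3)cc2)nc2sccc12`: compound 3 gives > 217000 nM, again a limit of the assay.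

Compound 3 thus stands at the top edge of what this assay reports, and it is not alone there: the limit of > 217000 nM in this assay, at which 2 of the 3 values shown sit. Only compound 2 returns a number. The step of an at least 45-fold higher number from compound 2 to compound 3 (1.66 log units; beyond the scatter) is large and beyond the scatter, whereas a step that the two limits leave unreadable from compound 1 to compound 3 rests on two limits and cannot be read.

Compound 4, `Cc1cc(/C=C/C#N)cc(C)c1Oc1nc(Nc2ccc(N3CCCC(NS(C)(=O)=O)C3)cc2)nc2sccc12`, differs from compound 3 by methyl in place of amino on a sulfonyl sulfur. Within the data shown here, none of the measured steps touches the sulfonyl sulfur; the steps that move the number all concern which group sits on the aromatic carbon, and the sulfamoyl to methylsulfonyl exchange has no measured counterpart. With compound 3 already at the limit, a step upward cannot be seen, and only a fall below the limit would register. The expectation for compound 4 is therefore a step of an at least 1.4-fold lower number from compound 3 to compound 4 (0.16 log units; that floor lies within the scatter) within the scatter, with a fair chance that this assay again reports only a limit. Compound 4 is estimated at 150000 nM, with a range of 30000 nM to 400000 nM.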

Compound 4, half-maximal cytotoxic concentration: 112000 nM
The estimate for compound 4 lay 1.3-fold (0.13 log units) above the measured number; low and high end bracket the measured number.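

Methyl in place of amino on a sulfonyl sulfur brings the read-out in this assay off the limit for the first time at this place, with an at least 1.9-fold lower number from compound 3 to compound 4 (0.28 log units; that floor lies within the scatter), so a number now exists for a 3-substituted piperidin-1-yl compound, though the printed floor of this step does not clear the scatter. The comparison with the other sulfamoyl compound has the same form, with an at least 1.9-fold lower number from compound 1 to compound 4 (0.28 log units; that floor lies within the scatter), while the comparison with the piperazin-1-yl compound stays large, with a 24-fold higher number from compound 2 to compound 4 (1.37 log units; beyond the scatter), so a sulfamoyl end is not required for a wide distance from compound 2. Compound 1 and compound 3 remain limits and not numbers: the limit of > 217000 nM in this assay, at which 2 of the 4 values shown sit.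

The compounds shown leave open how the number responds to other groups on the sulfonyl sulfur, such as ethyl or dimethylamino, and whether a plain amine in place of the sulfonamide nitrogen substituent would move the value toward that of compound 2. They also do not separate the sulfonyl group from the piperidine that carries it, as compound 2 differs from compound 4 in both at once.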